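Chain length in sulfoxide isothiocyanates against colon cancer cells

The source may report more compounds than this note shows. Statements on the series, on what has been measured and on what is new or still open speak of the compounds shown alone.

Three isothiocyanates carrying a sulfoxide have been tested on colon cancer cells. In a functional assay on HCT-116 cells (Homo sapiens) for cytotoxicity, read by MTT assay, with a stated time of 72 h (on this read-out lower numbers stand for stronger inhibition and higher numbers for weaker inhibition), compound 1 `CC(C)[S+]([O-])CCCCN=C=S` gives 3740 nM, and compound 3 `CC(C)[S+]([O-])CCCCCN=C=S` gives 3420 nM. The change between them is a group of 4 heavy atoms (2 carbon, 1 nitrogen, 1 sulfur; no ring) in place of a group of 3 heavy atoms (1 carbon, 1 nitrogen, 1 sulfur; no ring), on a saturated chain carbon, four bonds along the chain from a sulfur, and the step it made is a 1.1-fold lower number from compound 1 to compound 3 (0.04 log units; within the scatter). Compound 2 `[O-][S+](CCCCCN=C=S)Cc1ccccc1` gives 5190 nM in this assay; the difference between its core and that of compound 1 is not broken down here. Compound 4 `[O-][S+](CCCCCCN=C=S)Cc1ccccc1` is not yet measured. It differs from compound 2 by a group of 4 heavy atoms (2 carbon, 1 nitrogen, 1 sulfur; no ring) in place of a group of 3 heavy atoms (1 carbon, 1 nitrogen, 1 sulfur; no ring), on a saturated chain carbon, five bonds along the chain from a sulfur. This is the same kind of change as that from compound 1 to compound 3, though the place differs: five bonds along the chain from a sulfur rather than four. Because the earlier step was a 1.1-fold lower number from compound 1 to compound 3 (0.04 log units; within the scatter), the expected step is small, a 1.1-fold lower number from compound 2 to compound 4 (0.04 log units; within the scatter). Compound 4 is therefore estimated at 4700 nM, between 2500 nM and 9000 nM.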

Compound 4, half-maximal inhibitory concentration: 11600 nM
For compound 4 the middle estimate is 2.5-fold (0.39 log units) below the measured one; the whole stated range lies below it.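

In this assay, putting the longer chain in place of the shorter one gives a 2.2-fold higher number from compound 2 to compound 4 (0.35 log units; beyond the scatter), a modest step. Set beside the same change on the other core, the gap between the two steps is no firm sign that the cores respond differently: the same change on two cores in this assay, a 1.1-fold lower number (0.04 log units; within the scatter) from compound 1 to compound 3 and a 2.2-fold higher number (0.35 log units; beyond the scatter) from compound 2 to compound 4, 2.4-fold (0.39 log units) apart, within the scatter of two such steps. Nor does this prove that the change carries over faithfully, as each core offers only a single step, one within the scatter and one beyond it.

The compounds shown leave open whether a still longer chain would raise the number further on either core. They also leave open what would happen if an amine or a carboxylic acid stood in place of the isothiocyanate.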